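A few compounds are considered here, and "the series" means these few. Any claim that something is new, unique, unknown or untested is made for them only; others in the source may bear on it.

Working notes on the series. In a functional assay on Ehrlich cells (Mus musculus) for cytotoxicity, read by trypan blue exclusion, with a stated time of 24 h, tested at 100 uM (on this read-out higher numbers stand for a stronger effect at the one concentration tested and lower numbers for a weaker effect), compound 3 `CCN1C/C(=C\c2ccc(OC)cc2)C2=NN(c3nc(-c4ccc(Cl)cc4)cs3)C(c3ccc(OC)cc3)C2C1` gives 100%; compound 1 `CCN1C/C(=C\c2ccc(OC)cc2)C2=NN(C(N)=S)C(c3ccc(OC)cc3)C2C1` gives 99%, and compound 2 `N#Cc1c(N)nc2c(c1-c1ccc(O)cc1)CCC/C2=C\c1ccc(O)cc1` gives 81%. Compound 3 thus sits at the top of the three numbers, with compound 1 within the scatter of it and compound 2 well apart. Among the measured compounds shown here, the one single-point step measured so far, a number 1 percentage points higher from compound 1 to compound 3 (within the scatter), swaps a large group for a small one on the ring amine nitrogen and moves nothing beyond the scatter. For the measured compounds named here, compound 4 `COc1ccc(/C=C2\CN(C)CC3C2=NN(c2nc(-c4ccc(Cl)cc4)cs2)C3c2ccc(OC)cc2)cc1` differs from compound 3 by hydrogen in place of methyl on a saturated chain carbon bound to an amine nitrogen in a ring, a far smaller change at a different place; no measured step bears on it directly. The expected step is therefore a number 3 percentage points lower from compound 3 to compound 4 (within the scatter), none beyond the scatter. Compound 4 is estimated at 97%, within 86% to 100%.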

Compound 4, a percentage reported as activity, at one concentration (the size of the read-out at that concentration, not a potency): 97.9%
Compound 4: the middle estimate sits 0.9 percentage points below what was measured, and the stated range covers the measured number.
By their numbers in this assay, from the lowest: compound 2; then compounds 4, 1 and 3 (each within the scatter of the next).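

In this assay, hydrogen in place of methyl on a saturated chain carbon bound to an amine nitrogen in a ring gives a number 2.1 percentage points lower from compound 3 to compound 4 (within the scatter) and so shortens ethyl to methyl at this place without a step beyond the scatter. The read-out at one concentration gives the size of the effect, not a potency, so this step says nothing about potency at this place. Nothing measured here gives a reason for this result.

As far as these compounds go, how a longer chain such as butyl, or a carboxylic acid, would read at this place stays open.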